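This account rests on a few compounds, and the source may have more. Where it says the series, first, only, none or still open, it means among the compounds named here.

Measured compounds in a functional assay on the whole organism with Rattus norvegicus as the target, at a dose of 100 mg/kg; a higher number here means more inhibition at the dose given (going by the name of the read-out), a lower number less inhibition:
compound 1 `O=c1ccc(-c2ccccc2)nn1CCCNC(=S)Nc1ccccc1`, 12.1%
compound 2 `CC/N=C(/NC#N)NCCCCn1nc(-c2ccccc2)ccc1=O`, 58.8%

Compound 1 stands lowest of the two numbers: compound 2 lies far above it, a gap beyond the usual scatter. Compound 3 `O=c1ccc(-c2ccccc2)nn1CCCNC(=S)NC1CCCCC1` differs from compound 1 in one place: cyclohexyl in place of phenyl on an amide-type nitrogen. Among the measured compounds shown here, no measured pair shows this change, so nothing here tells how large its effect is. Compound 3 is therefore expected to stay close to compound 1, with a step of a number 4.9 percentage points higher from compound 1 to compound 3 (within the scatter) that need not exceed the scatter. The estimate for compound 3 in this assay is 17%, ranging from 2% to 40%.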

Compound 3, a percentage reported as inhibition, in the whole organism at one dose (the size of the read-out at that dose, not a potency): 23.6%
Compound 3: middle estimate off by 6.6 percentage points, on the low side, within the range that was stated.
By their numbers in this assay, from the lowest: compound 1; then compound 3; then compound 2.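

In this assay, the change from anilino to cyclohexylamino gives a number 11.5 percentage points higher from compound 1 to compound 3 (beyond the scatter) and so shows that this place on the amide-type nitrogen responds to the ring that sits on it. An aromatic ring of carbon only is not needed there, as the non-aromatic cyclohexyl ring of compound 3 holds the gain over compound 1. Nothing available explains this step. 

Still open, on these data alone, is how an open-chain group such as n-butyl, or a benzyl group, would behave on this nitrogen. Also open, as far as these compounds go, is what a carbonyl in place of the thiocarbonyl would do.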